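Removing a dodecyl stretch from compound 1

The source may hold more compounds than are shown below. What is called first, only, known or untested is meant among the compounds shown, and "the series" means these compounds.

Measured in a functional assay on K562 cells (Homo sapiens) for antiproliferative activity, read by MTT assay, with a stated time of 72 h; on this read-out higher numbers stand for weaker inhibition and lower numbers for stronger inhibition:
compound 1 `C/C=C1/[C@H](O[C@@H]2O[C@H](COC(C)=O)[C@@H](OC(C)=O)[C@H](OC(C)=O)[C@H]2OC(C)=O)OC=C(C(=O)OC)[C@H]1CC(=O)OCCCCCCCCCCCCCCC`: 7000 nM
compound 2 `C/C=C1/[C@H](O[C@@H]2O[C@H](CO)[C@@H](O)[C@H](O)[C@H]2O)OC=C(C(=O)OC)[C@H]1CC(=O)OCCC1CCCCC1`: 850 nM

Of these two numbers, compound 1 holds the higher, and it lies above that of compound 2 by more than the usual scatter of repeat measurements. Compound 3 `C/C=C1/[C@H](O[C@@H]2O[C@H](COC(C)=O)[C@@H](OC(C)=O)[C@H](OC(C)=O)[C@H]2OC(C)=O)OC=C(C(=O)OC)[C@H]1CC(=O)OCCC` has not yet been measured. It follows from compound 1 through the change (hydrogen in place of dodecyl on a saturated chain carbon, three bonds along the chain from an oxygen next to a carbonyl group), with hydrogen in place of dodecyl on a saturated chain carbon, three bonds along the chain from an oxygen next to a carbonyl group. Going by the values given here, no measured pair isolates this change, and compound 2 differs from compound 1 in more than one place. A small move toward a lower number in this assay is therefore expected, not clearly beyond the scatter. The estimated step is a 1.8-fold lower number from compound 1 to compound 3 (0.24 log units; within the scatter). Compound 3 is expected at 4000 nM, within an estimated range from 1200 nM to 15000 nM.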

Compound 3, half-maximal inhibitory concentration: 8500 nM
The estimate for compound 3 lay 2.1-fold (0.33 log units) below the measured number; low and high end bracket the measured number.
By their numbers in this assay, from the lowest: compound 2; then compounds 1 and 3 (each within the scatter of the next).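

Going by these compounds alone, the pair of compound 1 and compound 3 is the first to isolate this change: in this assay, hydrogen in place of dodecyl on a saturated chain carbon gives a 1.2-fold higher number from compound 1 to compound 3 (0.08 log units; within the scatter). With the rest of the structure held as in compound 1, the dodecyl stretch at this place can therefore go without a change beyond the usual scatter. No measurement at hand offers an explanation for this result.

From the compounds shown here alone, it remains open whether a different group at this place, such as an amine or a carboxylic acid, would shift the number in this assay, and whether the same holds on the background of compound 2. Compound 2 differs from compound 1 in more than one place, so which of those differences goes with its lower number also stays unresolved.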